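Trimming a Methylamino Group Down to Methyl

This account rests on a few compounds, and the source may have more. Where it says the series, first, only, none or still open, it means among the compounds named here.

Three close relatives of one shared core have been run through an ADME assay on microsomes from liver (Homo sapiens) for metabolic stability, with a stated time of 10 min; on this read-out lower numbers stand for a less stable compound and higher numbers for a more stable compound. Compound 1, `CC(C)(C)OC(=O)NCCS(=O)(=O)NC(=O)c1ccc(Nc2nc(NC3(c4ccc(Cl)cc4)CC3)nc(OCC(F)(F)F)n2)cc1`, gives 92%. Compound 2, `CC(C)S(=O)(=O)NC(=O)c1ccc(Nc2nc(NC3(c4ccc(Cl)cc4)CC3)nc(OCC(F)(F)F)n2)cc1`, gives 100% in this assay. Compound 3, `CNC(=O)NCCS(=O)(=O)NC(=O)c1ccc(Nc2nc(NC3(c4ccc(Cl)cc4)CC3)nc(OCC(F)(F)F)n2)cc1`, gives 97% in this assay. On these numbers compound 3 sits second of the three, yet every gap between them is within the scatter: a number 8 percentage points higher from compound 1 to compound 2 (within the scatter), a number 5 percentage points higher from compound 1 to compound 3 (within the scatter), and a number 3 percentage points lower from compound 2 to compound 3 (within the scatter).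

Compound 4, `CC(=O)NCCS(=O)(=O)NC(=O)c1ccc(Nc2nc(NC3(c4ccc(Cl)cc4)CC3)nc(OCC(F)(F)F)n2)cc1`, is the next relative and has not yet been measured. It differs from compound 3 in one place: methyl in place of methylamino on a carbonyl carbon. Within the data shown here, the change at this carbonyl carbon is of the same kind as the one from compound 1 to compound 3, where tert-butoxy gave way to methylamino with no shift beyond the scatter. None of the three measured steps, whether at the sulfonyl sulfur or at this carbonyl carbon, moved the read-out beyond the scatter.

The step from compound 3 to compound 4 is therefore expected to be a number 1 percentage points lower from compound 3 to compound 4 (within the scatter), nothing beyond the scatter. For compound 4 the estimate in this assay is 96%, in a range from 86% to 100%.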

Compound 4, percent of the compound remaining: 95%
Compound 4: middle estimate off by 1 percentage points, on the high side, and the stated range covers the measured number.
By their numbers in this assay, from the lowest: compounds 1, 4, 3 and 2 (each within the scatter of the next).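

In this assay, methyl in place of methylamino on a carbonyl carbon gives a number 2 percentage points lower from compound 3 to compound 4 (within the scatter) and so takes away the one hydrogen-bond donor of the leaving group without a shift beyond the scatter. This carbonyl carbon has now carried tert-butoxy, methylamino and methyl, and the direct comparison of the first and last of these gives a number 3 percentage points higher from compound 1 to compound 4 (within the scatter), while 2-acetamidoethyl in place of isopropyl on a sulfonyl sulfur gives a number 5 percentage points lower from compound 2 to compound 4 (within the scatter) and adds a further change at the sulfur that stays inside the scatter. Nothing available accounts for this lack of movement, so the result records tolerance of these particular groups and offers no explanation for it.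

The compounds shown leave open whether a longer chain such as ethyl or propyl on this carbonyl carbon, or a phenyl group there, would move the read-out beyond the scatter. They also leave open what would happen if the acetamido group gave way to a free amine or if a carboxylic acid stood at the end of the ethyl chain on the sulfonyl sulfur.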